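Fluoro addition on the aryl ether in a spirocyclic series

The source may report more compounds than this note shows. Statements on the series, on what has been measured and on what is new or still open speak of the compounds shown alone.

In a functional assay on cells for agonist activity at Glucose-dependent insulinotropic receptor (Homo sapiens), read by HTRF and cAMP accumulation, with a stated time of 30 min (a higher number here means that more compound is needed for the effect, a lower number that less compound is needed), compound 1 `CC(C)(C)OC(=O)N1CCC2(CC1)CC(CCCOc1ccc(S(C)(=O)=O)cc1)C2` gives 14 nM and compound 2 `CC(C)(C)OC(=O)N1CCC2(CC1)CC(CCCOc1ccc(S(C)(=O)=O)c(F)c1)C2` gives 9 nM. The change fluoro in place of hydrogen on an aromatic carbon made the step of a 1.6-fold lower number from compound 1 to compound 2 (0.19 log units; within the scatter). Compound 3 `CCc1cnc(N2CCC3(CC2)CC(CCCOc2ccc(S(C)(=O)=O)cc2)C3)nc1` gives 31 nM in this assay; its core differs from that of compound 1 by 5-ethylpyrimidin-2-yl in place of tert-butoxycarbonyl on an amine nitrogen in a ring, with the step of a 2.2-fold higher number from compound 1 to compound 3 (0.35 log units; beyond the scatter). Compound 4 `CCc1cnc(N2CCC3(CC2)CC(CCCOc2ccc(S(C)(=O)=O)cc2F)C3)nc1` is not yet measured in this assay. It differs from compound 3 by fluoro in place of hydrogen on an aromatic carbon, the same kind of change as from compound 1 to compound 2 but at a different place: here ortho to a large group and meta to a methylsulfonyl group, whereas earlier the fluoro entered ortho to a methylsulfonyl group and meta to a large group. A step of a 1.1-fold lower number from compound 3 to compound 4 (0.04 log units; within the scatter) is expected, resting on the earlier step of a 1.6-fold lower number from compound 1 to compound 2 (0.19 log units; within the scatter) that lay within the scatter. The different place weakens that inference. Compound 4 is estimated at 28 nM, expected between 12 nM and 65 nM.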

Compound 4, half-maximal effective concentration: 225 nM
For compound 4 the middle estimate is 8.0-fold (0.91 log units) below the measured one; the whole stated range lies below it.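

In this assay, fluoro in place of hydrogen gives a 7.3-fold higher number from compound 3 to compound 4 (0.86 log units; beyond the scatter), so this change does not carry as a fixed increment between these two cores: the same change on two cores in this assay, a 1.6-fold lower number (0.19 log units; within the scatter) from compound 1 to compound 2 and a 7.3-fold higher number (0.86 log units; beyond the scatter) from compound 3 to compound 4, 11-fold (1.05 log units) apart, beyond the scatter of two such steps The two steps differ in both the core and the place of the fluoro, here ortho to a large group and meta to a methylsulfonyl group, so the pair cannot tell whether the place, the core or both lie behind the gap. It shows the outcome of this one substitution on the core of compound 3, not a general rule for fluoro in the series.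

Open, from the compounds shown here alone, is how each fluoro place behaves on each core: the place in compound 2 on the core of compound 3, and the place in compound 4 on the core of compound 1, would separate the two. Also open, going by these compounds, is whether chloro or methoxy at the place in compound 4 would give a step like that of fluoro.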